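This account rests on a few compounds, and the source may have more. Where it says the series, first, only, none or still open, it means among the compounds named here.

Measured so far in a functional assay on HEp-2 cells (Homo sapiens) for inhibition, read by MTT assay, with a stated time of 72 h; on this read-out higher numbers stand for weaker inhibition and lower numbers for stronger inhibition:
compound 1 `C#CCCO[C@@H]1C=CC(=O)[C@@H](CO)O1` gives 7100 nM;
compound 2 `C=CCO[C@@H]1C=CC(=O)[C@@H](CO)O1` gives 26100 nM;
compound 3 `O=C1C=C[C@@H](OCc2ccccc2)O[C@@H]1CO` gives 8500 nM.

Compound 2 carries the highest number of the three: compound 3 sits at a lower number, and the step of a 3.7-fold higher number from compound 1 to compound 2 (0.57 log units; beyond the scatter) is also beyond the scatter. Compound 4 `CCCO[C@@H]1C=CC(=O)[C@@H](CO)O1` differs from compound 2 in one place: ethyl in place of vinyl on a saturated chain carbon bound to an oxygen on a saturated carbon. Going by the values given here, the only measured step touching this part of the molecule is a 3.7-fold higher number from compound 1 to compound 2 (0.57 log units; beyond the scatter), where propargyl gave way to vinyl; it changes the same chain but not in the same way, so it guides only loosely. The step of a 1.3-fold lower number from compound 2 to compound 4 (0.12 log units; within the scatter) is therefore expected to be small, toward a somewhat lower number. Compound 4 is estimated at 20000 nM, within 7000 nM to 55000 nM.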

Compound 4, half-maximal inhibitory concentration: 13400 nM
Estimate against measurement, compound 4: 1.5-fold (0.17 log units) above; the measured number falls inside the stated range.
By their numbers in this assay, from the lowest: compounds 1, 3, 4 and 2 (each within the scatter of the next, the first and the last beyond it).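

Replacing vinyl with ethyl gives a 1.9-fold lower number from compound 2 to compound 4 (0.29 log units; within the scatter) and so does not separate the allyloxy chain from the propoxy chain: the double bond of the chain is not shown to matter here. The other comparison, a 1.9-fold higher number from compound 1 to compound 4 (0.28 log units; within the scatter) as methyl replaces ethynyl, also stays inside the scatter. Compound 4 therefore lies within the scatter of both compound 1 and compound 2, even though those two differ beyond it.

On these data alone, whether a longer saturated chain, an amine or a carboxylic acid on this chain would move the number stays open. No measured evidence explains these steps.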